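The source may report more compounds than this note shows. Statements on the series, on what has been measured and on what is new or still open speak of the compounds shown alone.

Among the measured compounds shown here, compound 1 `CN1CCN(CC(=O)OC2CC3(N(C)C)CC(c4ccccc4)C2C(c2ccccc2)C3)CC1` is one of two compounds so far measured in an ADME assay on L6 cells (Rattus norvegicus) for cytotoxicity, read by resazurin assay, with a stated time of 72 h; on this read-out lower numbers stand for stronger inhibition and higher numbers for weaker inhibition. In this assay compound 1 gives 39900 nM, the lowest of the two numbers, though its nearest neighbour, compound 2 `CN1CCN(CC(=O)NC2CC3(N(C)C)CC(c4ccccc4)C2C(c2ccccc2)C3)CC1`, which in this assay gives 66200 nM, is separated from it only by a 1.7-fold higher number from compound 1 to compound 2 (0.22 log units; within the scatter), so the two numbers cannot be ordered. Compound 3 `CN1CCN(CC(=O)OC2CC3(N4CCCCC4)CC(c4ccccc4)C2C(c2ccccc2)C3)CC1` has not yet been measured in this assay. It differs from compound 1 by piperidin-1-yl in place of dimethylamino on a saturated ring carbon. For the measured compounds named here, the only measured step concerns a different change, the amide in place of the ester, and was a 1.7-fold higher number from compound 1 to compound 2 (0.22 log units; within the scatter); it does not bear on the exchange of the amino group, and no other pair in the set shows what that exchange does. Going by the values given here, with nothing to go on beyond the small size of the one measured step, no step beyond the scatter is expected, that is a 1.2-fold lower number from compound 1 to compound 3 (0.10 log units; within the scatter) is expected. Compound 3 is therefore estimated at 32000 nM, with a range from 10000 nM to 100000 nM.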

Compound 3, half-maximal inhibitory concentration: 29500 nM
For compound 3 the middle estimate is 1.1-fold (0.04 log units) above the measured one; measured number inside the range.
By their numbers in this assay, from the lowest: compounds 3, 1 and 2 (each within the scatter of the next, the first and the last beyond it).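

In this assay, the exchange of dimethylamino for piperidin-1-yl on this saturated ring carbon gives a 1.4-fold lower number from compound 1 to compound 3 (0.13 log units; within the scatter), so the two numbers cannot be ordered. Among the compounds shown here, the earlier compounds showed only the amide in place of the ester; this step is the first reading at the amino-bearing carbon, and it shows that an open dimethylamino group can give way to a six-membered non-aromatic ring there with no step beyond the scatter. No measurement at hand accounts for this result, and it is read here only as the size of the step.

What the compounds shown leave open is whether the same exchange would also stay within the scatter on the amide of compound 2, since that combination of the two changes does not appear among them. They also leave open whether other groups on this carbon, such as morpholin-4-yl with its ring oxygen, a smaller pyrrolidin-1-yl or a primary amine, would stay within the scatter of compound 1 or move the number beyond it.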